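Fluoroethenyl for methylbutenyl on the anilide carbonyl

The compounds below may be only part of what the source reports. "The series", "measured", "known", "first", "only" and "open" are said of these compounds alone.

Four compounds share one core, varied at two places. Compound 1 `CC(C)/C=C/C(=O)Nc1cccc(Oc2nc(Nc3ccn(C)n3)nc3c2CSCC3)c1` carries 3-methylbut-1-en-1-yl on the carbonyl carbon and 1-methyl-1H-pyrazol-3-yl on the ring nitrogen; compound 2 `C=C(F)C(=O)Nc1cccc(Oc2nc(Nc3ccn(C)n3)nc3c2CSCC3)c1` keeps the pyrazolyl and carries 1-fluoroethenyl; compound 3 `COc1cccc(Nc2nc3c(c(Oc4cccc(NC(=O)/C=C/C(C)C)c4)n2)CSCC3)c1` keeps the methylbutenyl and carries 3-methoxyphenyl; compound 4 `C=C(F)C(=O)Nc1cccc(Oc2nc(Nc3cccc(OC)c3)nc3c2CSCC3)c1` combines 3-methoxyphenyl with 1-fluoroethenyl and is not yet measured.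

In a functional assay on MCF7 cells (Homo sapiens) for antiproliferative activity, read by MTT assay, with a stated time of 72 h (on this read-out lower numbers stand for stronger inhibition and higher numbers for weaker inhibition), compound 1 reaches only a limit of the assay, > 50000 nM. Compound 2 likewise reaches only a limit, > 50000 nM. Going by the values given here, compound 3 gives 21800 nM, the only real number in the set.

The core change is 3-methoxyphenyl in place of 1-methyl-1H-pyrazol-3-yl on a nitrogen on an aromatic ring; it gives an at least 2.2-fold lower number from compound 1 to compound 3 (0.36 log units; beyond the scatter). The change of interest is 1-fluoroethenyl in place of 3-methylbut-1-en-1-yl on a carbonyl carbon; its step is a step that the two limits leave unreadable from compound 1 to compound 2, unreadable because of the limit of > 50000 nM in this assay, at which 2 of the 3 values shown sit. The same change, (1-fluoroethenyl in place of 3-methylbut-1-en-1-yl on a carbonyl carbon), is now made on the methoxyphenyl core; the two place descriptions agree word for word, so it is the same change.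

With the measured instance of the change uninformative, the expectation for compound 4 rests on compound 3 alone at 21800 nM, and the step from compound 3 to compound 4 is estimated near neutral, a 1.2-fold lower number from compound 3 to compound 4 (0.08 log units; within the scatter). Compound 4 is therefore estimated at 18000 nM, within 5000 nM to 50000 nM, with a real chance that only a limit is reported.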

Compound 4, half-maximal inhibitory concentration: > 50000 nM
Compound 4: no number, only a limit; the forecaster's own chance of this, stated with the estimate: 30%; middle value at least 2.7-fold (0.44 log units) from the limit.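

In this assay compound 4 reaches only a limit of the assay, > 50000 nM. On the core of compound 3, 1-fluoroethenyl in place of 3-methylbut-1-en-1-yl on a carbonyl carbon gives an at least 2.2-fold higher number from compound 3 to compound 4 (0.36 log units; beyond the scatter), so on this core the change weakens the read-out, by a size known only as a lower bound. The steps from compound 1 to compound 2 and from compound 2 to compound 4 cannot be read, so the change has a direction on one core only and its carrying over from one core to another is neither supported nor refuted, because most values in the set rest on the same limit: the limit of > 50000 nM in this assay, at which 3 of the 4 values shown sit.

Going by these compounds alone, compound 3, at 21800 nM, holds the only real number, so the series has no second measured point against which a step of this change could be set. Open, going by these compounds, is how a plain ethenyl, a longer chain or a chain ending in an amine on the carbonyl carbon would read on either core, and whether a group other than 3-methoxyphenyl or 1-methyl-1H-pyrazol-3-yl on the ring nitrogen would give numbers that can be compared at all.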